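Swapping nitro for methoxy on the pendant phenyl ring

This account rests on a few compounds, and the source may have more. Where it says the series, first, only, none or still open, it means among the compounds named here.

Measured compounds:
compound 1 `CSc1nc(NCCCCNc2ccnc3cc(Cl)ccc23)c(C#N)c(-c2cccc([N+](=O)[O-])c2)n1` with 2100 nM
compound 2 `CSc1nc(NCCCCNc2ccnc3cc(Cl)ccc23)c(C#N)c(-c2ccc([N+](=O)[O-])cc2)n1` with 960 nM

In an ADME assay on L1210 cells (Mus musculus) for inhibition, read by cell counting (on this read-out lower numbers stand for stronger inhibition and higher numbers for weaker inhibition), compound 1 gives 2100 nM and compound 2 gives 960 nM. Compound 2 therefore stands with the lower of the two numbers, the step of a 2.2-fold lower number from compound 1 to compound 2 (0.34 log units; beyond the scatter) lying beyond the scatter.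

Compound 3 `COc1ccc(-c2nc(SC)nc(NCCCCNc3ccnc4cc(Cl)ccc34)c2C#N)cc1` differs from compound 2 by methoxy in place of nitro on an aromatic carbon. For the measured compounds named here, the only measured step, a 2.2-fold lower number from compound 1 to compound 2 (0.34 log units; beyond the scatter), moved the nitro group from one position to another and did not replace it, so it bears on this change only loosely; no measured step exchanges the nitro for a different group. With the direction unknown, a modest shift either way is expected. Compound 3 is estimated to give 1500 nM. The range for compound 3 is expected to run from 400 nM to 6000 nM. The expected step is a 1.6-fold higher number from compound 2 to compound 3 (0.19 log units; within the scatter).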

Compound 3, half-maximal inhibitory concentration: 3200 nM
For compound 3 the middle estimate is 2.1-fold (0.33 log units) below the measured one, within the range that was stated.
By their numbers in this assay, from the lowest: compound 2; then compounds 1 and 3 (each within the scatter of the next).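

In this assay, exchanging nitro for methoxy on the same aromatic carbon, para to a large group, gives a 3.3-fold higher number from compound 2 to compound 3 (0.52 log units; beyond the scatter), so the number at this position depends on which group sits there and not only on where a nitro sits. The other new comparison, 4-methoxyphenyl in place of 3-nitrophenyl, gives a 1.5-fold higher number from compound 1 to compound 3 (0.18 log units; within the scatter), which leaves compound 2 alone with the lowest number of the three, its steps to both others lying beyond the scatter. No available evidence accounts for this shift.

The compounds shown leave open how an amine or a single fluorine atom on the same carbon would read. They also leave open whether methoxy would differ from nitro in the same way on the ring carbon that carries the nitro of compound 1.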